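The source may hold more compounds than are shown below. What is called first, only, known or untested is meant among the compounds shown, and "the series" means these compounds.

In an assay on HEK293 cells for positive allosteric modulation of metabotropic glutamate receptor 5 (Homo sapiens), read by FLIPR, with a stated time of 1 h (a lower number here means that less compound is needed, a higher number that more compound is needed for the effect), compound 2, `O=C(C1CCCC1)N1CCc2nc(C#Cc3ccccc3)sc2C1`, gives 19 nM, and compound 3, `O=C(C1CCCO1)N1CCc2nc(C#Cc3ccccc3)sc2C1`, gives 790 nM. Compound 1, `CCN1CCc2nc(C#Cc3ccccc3)sc2C1`, yields in this assay only a limit and no number, > 10000 nM, which is the limit of > 10000 nM in this assay, at which 1 of the 3 values shown sits. For the measured compounds named here, of the two numbers known, compound 3 stands highest; its nearest neighbour is compound 2, the gap between them being a 42-fold higher number from compound 2 to compound 3 (1.62 log units; beyond the scatter).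

Compound 4, `O=C(C1CCCCC1)N1CCc2nc(C#Cc3ccccc3)sc2C1`, has not yet been measured in this assay. Its difference from compound 3 is cyclohexyl in place of oxolan-2-yl on a carbonyl carbon. The measured step that bears most directly on it is a 42-fold higher number from compound 2 to compound 3 (1.62 log units; beyond the scatter), in which a cyclopentyl on the same carbonyl carbon was exchanged for the oxolan-2-yl; the change now under consideration runs the other way, replacing the oxolan-2-yl with a carbon-only ring again, cyclohexyl rather than cyclopentyl. The steps of an at least 520-fold lower number from compound 1 to compound 2 (2.72 log units; beyond the scatter) and an at least 12-fold lower number from compound 1 to compound 3 (1.10 log units; beyond the scatter) show that either carbonyl-bearing group on the ring nitrogen gives a far lower number than ethyl, though both rest on a limit.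

For compound 4 a large lowering is therefore expected, a 32-fold lower number from compound 3 to compound 4 (1.50 log units; beyond the scatter). The estimate for compound 4 in this assay is 25 nM, with a range from 8 nM to 80 nM.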

Compound 4, half-maximal effective concentration: 167 nM
Estimate against measurement, compound 4: 6.7-fold (0.82 log units) below; measured number above the stated range.
By their numbers in this assay, from the lowest: compound 2; then compound 4; then compound 3. At a limit, above all of these: compound 1.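

In this assay, the carbon-only ring on the carbonyl carbon cannot be swapped freely, since enlarging it from cyclopentyl to cyclohexyl already gives an 8.8-fold higher number from compound 2 to compound 4 (0.94 log units; beyond the scatter). Going from oxolan-2-yl to cyclohexyl gives a 4.7-fold lower number from compound 3 to compound 4 (0.67 log units; beyond the scatter), so a ring of carbon only improves on the oxolan-2-yl here, yet by the printed values compound 4 does not reach compound 2, and the absence of the ring oxygen alone does not restore the low number. The carbonyl-bearing group on the ring nitrogen again compares well with ethyl in an at least 59-fold lower number from compound 1 to compound 4 (1.77 log units; beyond the scatter), though that step rests on compound 1, which gives a limit and not a number: the limit of > 10000 nM in this assay, at which 1 of the 4 values shown sits.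

Cyclohexyl differs from oxolan-2-yl in both ring size and the ring oxygen, so the step from compound 3 to compound 4 cannot separate the two changes, and an oxan-2-yl group, a six-membered ring with one oxygen, would be needed to do so. Whether the low number is specific to cyclopentyl also stays open, as a smaller carbon ring such as cyclobutyl or an open chain such as isopropyl does not appear among these compounds.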